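Permeability of an Isopropyl Analogue, Before the Measurement

The source may report more compounds than this note shows. Statements on the series, on what has been measured and on what is new or still open speak of the compounds shown alone.

Compound 1 `CNC(=O)c1cc(Oc2ccc3nc(Nc4cccc(C(C)(C)C)c4)ncc3c2)ccn1` gives < 1 10^-6 cm/s in an ADME assay on Caco-2 cells (Homo sapiens) for permeability, in the apical to basolateral direction (on this read-out higher numbers stand for higher permeability and lower numbers for lower permeability), which is a limit of the assay and not a number.
Compound 2 `CCc1ccccc1Nc1ncc2cc(Oc3ccnc(C(=O)NC)c3)ccc2n1` gives < 1 10^-6 cm/s in this assay, again a limit.
Compound 3 `CNC(=O)c1cc(Oc2ccc3nc(Nc4cccc(OC(F)(F)F)c4)ncc3c2)ccn1` gives < 1 10^-6 cm/s in this assay, also a limit.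

Compound 3 therefore stands where every measured compound stands: the limit of < 1 10^-6 cm/s in this assay, at which 3 of the 3 values shown sit. For the measured compounds named here, since no compound has a number, the three measured steps, a step that the two limits leave unreadable from compound 1 to compound 2, a step that the two limits leave unreadable from compound 1 to compound 3 and a step that the two limits leave unreadable from compound 2 to compound 3, cannot be sized; they show only that swapping one group on the amine-bound phenyl for another left each compound at the limit. Compound 4 `CNC(=O)c1cc(Oc2ccc3nc(Nc4cccc(C(C)C)c4)ncc3c2)ccn1` differs from compound 3 by isopropyl in place of trifluoromethoxy on an aromatic carbon. The measured steps bear on this change only loosely, as all three concern the same position and none moved a compound off the limit. A step of size a step that the limit leaves unreadable from compound 3 to compound 4 is expected, meaning compound 4 is expected to remain at or near the limit in this assay. The estimate for compound 4 is 0.7 10^-6 cm/s, with a range from 0.2 10^-6 cm/s to 2.5 10^-6 cm/s, and a limit-only result is considered the most likely outcome.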

Compound 4, apparent permeability: < 1 10^-6 cm/s
Compound 4: only a limit was reported; the forecaster's own chance of this, stated with the estimate: 70%; the middle value is on the limit's open side.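

No step from compound 1, compound 2 or compound 3 to compound 4 can be read, since each result is a limit and not a number: the limit of < 1 10^-6 cm/s in this assay, at which 4 of the 4 values shown sit.

The compounds shown leave open how these four compounds truly rank in this assay, and which change, if any, would give a readable number.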